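The compounds below may be only part of what the source reports. "The series", "measured", "known", "first", "only" and "open" are said of these compounds alone.

Measured in an ADME assay on RAW264.7 cells (Mus musculus) for cytotoxicity, read by MTT assay, with a stated time of 24 h; on this read-out higher numbers stand for lower toxicity in this test and lower numbers for higher toxicity in this test:
- Compound 1 `CC/C=C\C[C@H]1C(=O)C=C[C@H]1CC(=O)OCCC`: 35 uM
- Compound 2 `CC/C=C\C[C@H]1C(=O)C=C[C@H]1CC(=O)OCCCCC`: 37 uM
- Compound 3 `CC/C=C\C[C@H]1C(=O)C=C[C@H]1CC(=O)OCCOCCO`: 166 uM

Of these three, compound 3 stands highest, at 166 uM. Compound 4 `CC/C=C\C[C@H]1C(=O)C=C[C@H]1CC(=O)OCCOCCOCCO` departs from it by 2-hydroxyethyl in place of hydrogen on an oxygen on a saturated carbon. Going by the values given here, no measured step makes this same change. The nearest evidence is a 4.7-fold higher number from compound 1 to compound 3 (0.68 log units; beyond the scatter) and a 4.5-fold higher number from compound 2 to compound 3 (0.65 log units; beyond the scatter), both of which introduced 2-hydroxyethoxy. Lengthening the plain chain gave only a 1.1-fold higher number from compound 1 to compound 2 (0.02 log units; within the scatter). A smaller rise than those two steps is therefore expected, possibly within the scatter. The expected step is a 1.3-fold higher number from compound 3 to compound 4 (0.12 log units; within the scatter). For compound 4 the estimate is 220 uM, with an expected range from 110 uM to 450 uM.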

Compound 4, half-maximal toxic concentration: 162 uM
Compound 4: the middle estimate sits 1.4-fold (0.13 log units) above what was measured; measured number inside the range.
By their numbers in this assay, from the lowest: compounds 1 and 2 (each within the scatter of the next); then compounds 4 and 3 (each within the scatter of the next).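

In this assay, 2-hydroxyethyl in place of hydrogen on an oxygen on a saturated carbon gave a 1.0-fold lower number from compound 3 to compound 4 (0.01 log units; within the scatter), so at this position the extension adds nothing that can be told from the scatter. The rise over the plain chains holds with 2-(2-hydroxyethoxy)ethoxy, at a 4.4-fold higher number from compound 2 to compound 4 (0.64 log units; beyond the scatter) and a 4.6-fold higher number from compound 1 to compound 4 (0.67 log units; beyond the scatter). Nothing available explains this flat step. The compounds shown leave open whether an amine or a carboxylic acid in place of the hydroxy would keep the number at this level, and whether a still longer chain of the same kind would do so.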